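The source may report more compounds than this note shows. Statements on the series, on what has been measured and on what is new or still open speak of the compounds shown alone.

Three imines built on one shared core were tested in a functional assay, with a stated time of 30 min; on this read-out higher numbers stand for weaker inhibition and lower numbers for stronger inhibition. Compound 1 `Oc1ccc(/C=N/c2ccc(OCc3ccccc3)cc2)c(O)c1` is recorded there only as a limit of the assay, > 200000 nM. Compound 2 `Oc1ccc(Br)cc1/C=N/c1ccc(OCc2ccccc2)cc1` likewise reaches only the limit > 200000 nM. Compound 3 `Oc1ccc(F)cc1/C=N/c1ccc(OCc2ccccc2)cc1` also stops at the limit > 200000 nM. Because of the limit of > 200000 nM in this assay, at which 3 of the 3 values shown sit, the steps a step that the two limits leave unreadable from compound 1 to compound 2, a step that the two limits leave unreadable from compound 1 to compound 3 and a step that the two limits leave unreadable from compound 2 to compound 3 cannot be given a size. Compound 4 `Oc1cc(O)c(/C=N/c2ccc(OCc3ccccc3)cc2)c(O)c1` has not yet been measured; it differs from compound 1 by hydroxy in place of hydrogen on an aromatic carbon. Going by the values given here, since none of the measured steps is readable, no direction can be drawn from them. Compound 4 is expected to sit again at the limit, estimated at 300000 nM within a range from 60000 nM to 1500000 nM. The expected step that the limit leaves unreadable from compound 1 to compound 4 is thus one of no change beyond the scatter.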

Compound 4, half-maximal inhibitory concentration: 23900 nM
Compound 4: the middle estimate sits 13-fold (1.10 log units) above what was measured; the whole stated range lies above it.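

Of the steps shown, only one can be read: in this assay, hydroxy in place of hydrogen, on the aromatic carbon ortho to a large group and meta to two hydroxy groups, gives an at least 8.3-fold lower number from compound 1 to compound 4 (0.92 log units; beyond the scatter). This position therefore responds to change, and one added hydroxy is enough to bring a compound off the limit. The earlier steps could not show this because their values all stop there: the limit of > 200000 nM in this assay, at which 3 of the 4 values shown sit.

Still open, going by these compounds, is whether an amine or a methoxy group at this position would do the same. Also open, on these data alone, is whether the new hydroxy would give such a step without the two hydroxy groups already on that ring.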